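This account rests on a few compounds, and the source may have more. Where it says the series, first, only, none or still open, it means among the compounds named here.

Compound 2 `CCS(=O)(=O)Nc1ccc(Oc2cc(F)c(F)c(F)c2)c(-c2cn(C)c(=O)c3cncn23)c1` carries a 3,4,5-trifluorophenyl group on an oxygen on an aromatic ring. In an ADME assay on microsomes from liver (Mus musculus) for metabolic stability, with a stated time of 40 min, tested at 10 uM (a lower number here means that less of the compound is left, a higher number that more of the compound is left), compound 2 gives 36%, the second highest of three numbers: compound 1 `Cn1cc(-c2cc(NS(C)(=O)=O)ccc2Oc2ccc(Br)cc2)n2cncc2c1=O` gives 61.2%, while compound 3 `CCS(=O)(=O)Nc1ccc(Oc2cc(C)ccc2F)c(-c2cn(C)c(=O)c3cncn23)c1` gives 4.6%. For the measured compounds named here, only one measured step bears on the present change, and it was large: a number 31.4 percentage points lower from compound 2 to compound 3 (beyond the scatter). Compound 4 `CCS(=O)(=O)Nc1ccc(Oc2cc(F)ccc2C)c(-c2cn(C)c(=O)c3cncn23)c1` differs from compound 2 in a closely related way, (5-fluoro-2-methylphenyl in place of 3,4,5-trifluorophenyl on an oxygen on an aromatic ring), so that, like compound 3, it carries a fluoro-methylphenyl rather than a trifluorophenyl on that oxygen. Because of a number 31.4 percentage points lower from compound 2 to compound 3 (beyond the scatter), a downward step of comparable size is expected, a number 26 percentage points lower from compound 2 to compound 4 (beyond the scatter). Compound 4 is therefore estimated at 10%, within a range from 2% to 30%.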

Compound 4, percent of the compound remaining: 11.2%
For compound 4 the middle estimate is 1.2 percentage points below the measured one, within the range that was stated.
By their numbers in this assay, from the lowest: compounds 3 and 4 (each within the scatter of the next); then compound 2; then compound 1.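

In this assay, a second fluoro-methylphenyl group on this oxygen also falls well short of the 3,4,5-trifluorophenyl group, with a number 24.8 percentage points lower from compound 2 to compound 4 (beyond the scatter). The two fluoro-methylphenyl groups cannot be told apart, since 5-fluoro-2-methylphenyl in place of 2-fluoro-5-methylphenyl gives a number 6.6 percentage points higher from compound 3 to compound 4 (within the scatter). No measurement shown here explains the loss that comes with either group. Still open, on these data alone, is how a pyridine ring or a plain, unsubstituted phenyl on this oxygen would fare, and whether a methyl group on a ring that also carries three fluorines would lower the number.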